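The compounds below may be only part of what the source reports. "The series", "measured", "known", "first", "only" and "open" are said of these compounds alone.

Measured so far:
Compound 1 `CCCCCCCCCCn1cc(COC[C@@H]2OC[C@H](N)[C@@H]2O)nn1` gives 15600 nM
Compound 2 `CCCCCCCCCCCCCCCCn1cc(COC[C@@H]2OC[C@H](N)[C@@H]2O)nn1` gives 20000 nM

In a functional assay on EC9706 cells (Homo sapiens) for antiproliferative activity, read by MTT assay, with a stated time of 48 h (a higher number here means a weaker inhibitor, a lower number a stronger inhibitor), compound 2 stands at 20000 nM and cannot be told apart from compound 1. Within the data shown here, the only measured step, a 1.3-fold higher number from compound 1 to compound 2 (0.11 log units; within the scatter), stays within the usual scatter of repeated measurements. That step is hexyl in place of hydrogen on a saturated chain carbon, ten or more bonds along the chain from an aromatic nitrogen.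

Compound 3 `CCCCCCCCCCCCCCCCCCn1cc(COC[C@@H]2OC[C@H](N)[C@@H]2O)nn1` keeps the shared core and differs from compound 2 by ethyl in place of hydrogen on a saturated chain carbon, ten or more bonds along the chain from an aromatic nitrogen at the same kind of carbon. Among the measured compounds shown here, this is a smaller addition of the same sort, so the one measured step bears directly on it. A single pair of compounds shows no trend, however, and nothing measured says how far the chain can grow before the number moves. No step beyond the scatter is therefore expected in this assay, and no firm direction. The estimate means a 1.1-fold higher number from compound 2 to compound 3 (0.04 log units; within the scatter) as the expected step. Compound 3 is estimated at 22000 nM, with an expected range from 11000 nM to 45000 nM for repeated measurements.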

Compound 3, half-maximal inhibitory concentration: 17800 nM
Estimate against measurement, compound 3: 1.2-fold (0.09 log units) above; the range from low to high includes it.
By their numbers in this assay, from the lowest: compounds 1, 3 and 2 (each within the scatter of the next).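

Until now a single pair of compounds spoke for this position, and one pair cannot show whether a longer chain matters at all. In this assay, ethyl in place of hydrogen on a saturated chain carbon, ten or more bonds along the chain from an aromatic nitrogen, gives a 1.1-fold lower number from compound 2 to compound 3 (0.05 log units; within the scatter) and octyl in the same kind of place gives a 1.1-fold higher number from compound 1 to compound 3 (0.06 log units; within the scatter) so that even the largest addition among these compounds leaves the number within the scatter, and across compounds 1, 2 and 3 chain length shows no trend in either direction, with none of the three going against this. Nothing measured alongside these numbers offers an explanation for this flat result.

As far as these compounds go, whether a much shorter chain, such as butyl, or a chain ending in an amine or a carboxylic acid would move the number beyond the scatter remains open. Also open is how a change elsewhere on the shared core, rather than on the chain, would read in this assay since every compound shown keeps that core unchanged.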